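This account rests on a few compounds, and the source may have more. Where it says the series, first, only, none or still open, it means among the compounds named here.

Among the compounds with values here, compound 2 `CC(=O)O[C@@H]1[C@H]2OC(C)(C)O[C@H]2O[C@@H]1C(=O)c1cnc2sc(C(=O)c3ccc(Cl)cc3)cn12` is the one compound with a number in an ADME assay on Vero cells (Chlorocebus sabaeus) for cytotoxicity, read by MTT assay, with a stated time of 48 h (a lower number here means that less compound is tolerated, a higher number that more compound is tolerated), where compound 2 gives 70000 nM. Compound 1 `CO[C@@H]1[C@H]2OC(C)(C)O[C@H]2O[C@@H]1C(=O)c1cnc2sc(C(=O)c3ccc(F)cc3)cn12` reaches only a limit in this assay, reported as > 400000 nM. Compound 3 `CC(=O)O[C@@H]1[C@H]2OC(C)(C)O[C@H]2O[C@@H]1C(=O)c1cnc2sc(C(=O)c3ccc(F)cc3)cn12` differs from compound 2 by fluoro in place of chloro on an aromatic carbon. Within the data shown here, no measured pair covers this change, so nothing beyond the usual scatter is expected in this assay; if anything, the shift should run toward more compound tolerated. Compound 3 is estimated at 100000 nM, within 40000 nM to 300000 nM, the expected step being a 1.4-fold higher number from compound 2 to compound 3 (0.15 log units; within the scatter).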

Compound 3, half-maximal cytotoxic concentration: > 400000 nM
Compound 3: only a limit was reported; the forecaster's own chance of this, stated with the estimate: 25%; middle value at least 4.0-fold (0.60 log units) from the limit.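

In this assay, fluoro in place of chloro on this aromatic carbon, with the acetyl on the oxygen unchanged, gives an at least 5.7-fold higher number from compound 2 to compound 3 (0.75 log units; beyond the scatter). Within the data shown here, this single-atom change at the position para to a large group is therefore enough to separate the one compound with a number from a compound at the limit. The step is only a minimum, its true size being hidden by the limit: the limit of > 400000 nM in this assay, at which 2 of the 3 values shown sit.

The step between methyl and acetyl on the oxygen cannot be read, as compound 1 and compound 3 are both limits. Going by these compounds, whether bromo or an amine at this place would behave like chloro or like fluoro stays open.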